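Aryl oxobutenoic acids: bromo to butyl step

The source may hold more compounds than are shown below. What is called first, only, known or untested is meant among the compounds shown, and "the series" means these compounds.

Measured so far:
compound 1 `CC(C)c1cc(C(C)C)c(C(=O)/C=C/C(=O)O)c(C(C)C)c1` — 8280 nM
compound 2 `CC(C)c1ccc(C(C)C)c(C(=O)/C=C/C(=O)O)c1` — 6230 nM
compound 3 `O=C(O)/C=C/C(=O)c1ccc(Br)cc1` — 27100 nM

In a functional assay on LS174T cells (Homo sapiens) for inhibition, read by MTT assay, with a stated time of 72 h (on this read-out lower numbers stand for stronger inhibition and higher numbers for weaker inhibition), compound 3 stands highest of the three numbers; compound 1 sits nearest with a lower number and compound 2 furthest, both gaps beyond the scatter. Compound 4 `CCCCc1ccc(C(=O)/C=C/C(=O)O)cc1` is not yet measured. It differs from compound 3 by butyl in place of bromo on an aromatic carbon, on an aromatic carbon of a six-membered aromatic ring of carbon only. Compounds 1 and 2, which carry alkyl groups on the same core, give lower numbers than compound 3 in this assay, so a moderate step downward is expected, though no shown step covers this exact change. Compound 4 is estimated at 12000 nM (range 4000 nM to 35000 nM), which is an expected step of a 2.3-fold lower number from compound 3 to compound 4 (0.35 log units; beyond the scatter).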

Compound 4, half-maximal inhibitory concentration: 6740 nM
For compound 4 the middle estimate is 1.8-fold (0.25 log units) above the measured one; low and high end bracket the measured number.
By their numbers in this assay, from the lowest: compounds 2, 4 and 1 (each within the scatter of the next); then compound 3.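

In this assay, among these compounds, butyl in place of bromo on an aromatic carbon gives a 4.0-fold lower number from compound 3 to compound 4 (0.60 log units; beyond the scatter) and is the first step that changes one place only. The position para to a group of 7 heavy atoms therefore accepts an all-carbon chain, and the change lowers the number beyond the scatter. Nothing available accounts for the step.

Open, going by these compounds, is whether the number keeps moving with a shorter chain such as ethyl or a longer one such as hexyl. Also open, on these data alone, is how an amine or a hydroxyl group would read at this position.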